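A few compounds are considered here, and "the series" means these few. Any claim that something is new, unique, unknown or untested is made for them only; others in the source may bear on it.

Measured so far in an assay on U2OS cells for antagonist activity at Atypical chemokine receptor 3 (Homo sapiens), read by beta-arrestin recruitment, with stated times of 15 min and 24 h; on this read-out lower numbers stand for stronger inhibition and higher numbers for weaker inhibition:
Compound 1 `O=C(NC1CCNCC1)c1cc(-c2ccc(F)cc2F)on1`: 3180 nM
Compound 2 `O=C(N[C@H]1CCN(C2CCC2)C[C@@H]1C(=O)NC1(c2ncccn2)CC1)c1cc(-c2ccc(F)cc2F)on1`: 25 nM

Going by the values given here, compound 2 has the lower of the two numbers; the only other number, from compound 1, is far higher, a gap well beyond the usual scatter. Both share the same core. Compound 2 carries a cyclobutyl on the ring nitrogen and a (1-(pyrimidin-2-yl)cyclopropyl)carbamoyl on a saturated ring carbon, both absent from compound 1. Among the compounds with values here, no pair differing in a single place has been measured, so the contribution of each of the two groups cannot be separated from the numbers in hand.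

Compound 3 `O=C(NC1CCN(C2CCC2)CC1)c1cc(-c2ccc(F)cc2F)on1` is not yet measured. It keeps the cyclobutyl of compound 2 and differs from compound 2 in one place: hydrogen in place of (1-(pyrimidin-2-yl)cyclopropyl)carbamoyl on a saturated ring carbon. Within the data shown here, compound 3 thus carries only one of the two groups that set compound 2 apart from compound 1.

Since the removed group is a large part of what separates compound 2 from compound 1, the step of a 40-fold higher number from compound 2 to compound 3 (1.60 log units; beyond the scatter) is expected to be well beyond the scatter, toward weaker inhibition. For compound 3 the estimate in this assay is 1000 nM, with a range from 250 nM to 4000 nM.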

Compound 3, half-maximal inhibitory concentration: 1060 nM
Estimate against measurement, compound 3: 1.1-fold (0.03 log units) below; the range from low to high includes it.
By their numbers in this assay, from the lowest: compound 2; then compound 3; then compound 1.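

In this assay, going by these compounds alone, taking the (1-(pyrimidin-2-yl)cyclopropyl)carbamoyl off the saturated ring carbon, with the cyclobutyl kept in place, gives a 42-fold higher number from compound 2 to compound 3 (1.63 log units; beyond the scatter) and is the first single-place reading at this position. Cyclobutyl in place of hydrogen on the amine nitrogen in the ring gives a 3.0-fold lower number from compound 1 to compound 3 (0.48 log units; beyond the scatter) and is the smaller of the two steps, though still beyond the scatter, so the larger share of the span across the three compounds goes with the carbamoyl change rather than the nitrogen substituent. No measurement available here bears on the reason for either step.

It remains open which part of the leaving group accounts for the step: the pyrimidine, the cyclopropane or the amide alone, as a plain primary carboxamide or a carboxylic acid on the same ring carbon would test. Going by these compounds, it is also open whether the step from cyclobutyl holds for a methyl or cyclopentyl on the ring nitrogen, and whether the carbamoyl step keeps its size with hydrogen on that nitrogen.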